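Changing the aromatic ring of compound 2

The source may hold more compounds than are shown below. What is called first, only, known or untested is meant among the compounds shown, and "the series" means these compounds.

In a functional assay on DU-145 cells (Homo sapiens) for inhibition, read by trypan blue exclusion, with a stated time of 96 h (a lower number here means a stronger inhibitor of growth, a higher number a weaker inhibitor of growth), compound 1 (`O=C(/C(=C\c1ccc(O)c([N+](=O)[O-])c1)SCc1ccc(Br)cc1)c1ccc(Br)cc1`) gives 10000 nM and compound 2 (`O=C(/C(=C\c1ccc([N+](=O)[O-])c(O)c1)SCc1ccc(Br)cc1)c1ccc(Br)cc1`) gives 10000 nM, so compound 2 stands level with compound 1. Among the compounds with values here, the only measured step, no change at the digits printed from compound 1 to compound 2 (within the scatter), exchanges 4-hydroxy-3-nitrophenyl for 3-hydroxy-4-nitrophenyl. Compound 3 (`O=C(/C(=C\c1cc(Br)c(O)c(Br)c1)SCc1ccc(Br)cc1)c1ccc(Br)cc1`) has not yet been measured. It carries 3,5-dibromo-4-hydroxyphenyl in place of 3-hydroxy-4-nitrophenyl on a double-bonded chain carbon bound to a double-bonded chain carbon. The measured step kept the nitro group, whereas this change removes it, so that step is only a weak guide. Within the data shown here, no measured compound carries bromine on this ring. No step beyond the scatter is therefore expected in this assay, and no direction can be firmly predicted. The expected change is a 1.3-fold lower number from compound 2 to compound 3 (0.10 log units; within the scatter). For compound 3 the estimate is 8000 nM, with an expected range from 2000 nM to 20000 nM.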

Compound 3, concentration for 50% growth inhibition: 1000 nM
The estimate for compound 3 lay 8.0-fold (0.90 log units) above the measured number; the whole stated range lies above it.
By their numbers in this assay, from the lowest: compound 3; then compounds 1 and 2 (each within the scatter of the next).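

This aryl group, on a double-bonded chain carbon bound to a double-bonded chain carbon, can change growth inhibition in this assay, which moving the hydroxyl and nitro groups around the ring had not shown. Putting 3,5-dibromo-4-hydroxyphenyl in place of either nitro-bearing ring lowers the number by the same amount (a 10-fold lower number from compound 2 to compound 3 (1.00 log units; beyond the scatter) and a 10-fold lower number from compound 1 to compound 3 (1.00 log units; beyond the scatter)), making compound 3 the strongest inhibitor of the three. No measurement here explains why the dibrominated ring does better.

This single change removes the nitro group and adds two bromines, so the compounds shown cannot separate the two effects. Also open, as far as these compounds go, is how a ring with one bromine, two chlorines or a methoxy group in place of the hydroxyl would compare with compound 3.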